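Swapping the acyl group on a dodecyl threonine amide

This account rests on a few compounds, and the source may have more. Where it says the series, first, only, none or still open, it means among the compounds named here.

Compound 1 `CCCCCCCCCCCCNC(=O)[C@@H](NC(=O)c1ccccc1)[C@@H](C)O`, compound 2 `CCCCCCCCCCCCNC(=O)[C@@H](NC(=O)c1ccco1)[C@@H](C)O` and compound 3 `CCCCCCCCCCCCNC(=O)[C@@H](NC(=O)c1nccc2ccccc12)[C@@H](C)O` share one core and differ only in the group attached to the carbonyl carbon of the amide on the threonine-derived nitrogen. In a functional assay on A-431 cells (Homo sapiens) for cytotoxicity, read by MTT assay, with a stated time of 48 h (on this read-out higher numbers stand for weaker inhibition and lower numbers for stronger inhibition), compound 1 gives 41200 nM, compound 2 gives 92400 nM and compound 3 gives 62800 nM. Compound 3 thus sits second highest of the three, and its distance to each neighbour is small: a 1.5-fold higher number from compound 1 to compound 3 (0.18 log units; within the scatter) and a 1.5-fold lower number from compound 2 to compound 3 (0.17 log units; within the scatter) both stay within the scatter, while a 2.2-fold higher number from compound 1 to compound 2 (0.35 log units; beyond the scatter) is only modest.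

Compound 4 `CCCCCCCCCCCCNC(=O)[C@@H](NC(=O)/C=C/c1ccccc1)[C@@H](C)O` changes the same position again: 2-phenylethenyl in place of isoquinolin-1-yl on a carbonyl carbon. The three measured steps are the ones that bear on this, since each of them also exchanged the whole group on that carbonyl carbon, and none moved the number by more than a modest amount. A change of similar size is therefore expected in this assay for compound 4, with no clear direction, and most likely one that does not reach beyond the scatter. Compound 4 is estimated at 50000 nM, within a range from 22000 nM to 110000 nM, which means an expected step of a 1.3-fold lower number from compound 3 to compound 4 (0.10 log units; within the scatter).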

Compound 4, half-maximal inhibitory concentration: > 200000 nM
Compound 4 gave a limit, no number (the forecaster's own chance of this, stated with the estimate: 10%); middle value at least 4.0-fold (0.60 log units) away from the limit.
By their numbers in this assay, from the lowest: compounds 1, 3 and 2 (each within the scatter of the next, the first and the last beyond it). At a limit, above all of these: compound 4.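

In this assay, compound 4 gives a limit and not a number: the limit of > 200000 nM in this assay, at which 1 of the 4 values shown sits.

The earlier exchanges at this carbonyl carbon stayed within a modest span, but 2-phenylethenyl moves the read-out further, with each step beyond the scatter and each only a lower bound on the true step: an at least 3.1-fold higher number from compound 3 to compound 4 (0.50 log units; beyond the scatter), an at least 2.1-fold higher number from compound 2 to compound 4 (0.33 log units; beyond the scatter) and an at least 4.8-fold higher number from compound 1 to compound 4 (0.68 log units; beyond the scatter). This position is therefore less tolerant than the phenyl, furan-2-yl and isoquinolin-1-yl compounds alone suggested, since the choice of group here can weaken the cytotoxic read-out by more than those three exchanges did.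

Among the compounds shown here, how far the true value of compound 4 lies past its limit remains unknown, and 2-phenylethenyl is the only group here with a double bond outside aromatic rings, so a single compound cannot show whether that double bond or the rest of the exchange accounts for the step. The compounds shown also leave open how a 2-phenylethyl group, which lacks that double bond, or an acyl group carrying an amine or a carboxylic acid would behave on the same carbonyl carbon.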